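Working notes: from compound 2 to compound 3

This account rests on a few compounds, and the source may have more. Where it says the series, first, only, none or still open, it means among the compounds named here.

- compound 1 `CCOCCCCc1cc(=O)c2cc([N+](=O)[O-])ccc2[nH]1`: 50000 nM
- compound 2 `CCCCCOCc1[nH]c2ccc([N+](=O)[O-])cc2c(=O)c1C(=O)O`: 50000 nM

In a physicochemical assay for solubility, read by HPLC, at pH 7.4 (on this read-out lower numbers stand for lower solubility and higher numbers for higher solubility), compound 2 gives 50000 nM and stands level with compound 1 at 50000 nM, within the usual scatter. Among the measured compounds shown here, these two compounds differ in more than one place, so the series offers no measured single-change step to size what follows.

Compound 3 `CCOCCCCc1[nH]c2ccc([N+](=O)[O-])cc2c(=O)c1C(=O)O` has the same atoms as compound 2, joined differently: 3-ethoxypropyl in place of pentyloxy on a saturated chain carbon bound to an aromatic carbon. In words, this is 3-ethoxypropyl in place of pentyloxy on a saturated chain carbon bound to an aromatic carbon. Cut one bond further out, the same difference reads (pentyloxy)methyl to 4-ethoxybutyl.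

For the measured compounds named here, the only guide is thin: compound 1 already carries the 4-ethoxybutyl chain and gives 50000 nM. On that basis, the expected step of no change at the digits printed from compound 2 to compound 3 (within the scatter) is none beyond the scatter in this assay, with no direction favoured. For compound 3 the estimated value is 50000 nM, with an expected range of 25000 nM to 100000 nM.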

Compound 3, solubility: 50000 nM
The estimate for compound 3 equals the measured number at the digits printed, within the range that was stated.
By their numbers in this assay, from the lowest: compounds 1, 2 and 3 (each within the scatter of the next).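

In this assay the step of no change at the digits printed from compound 2 to compound 3 (within the scatter) gives the series its first measured single-change read at this position: 3-ethoxypropyl in place of pentyloxy on a saturated chain carbon bound to an aromatic carbon. Compound 3 also supplies a second single-change read, carboxy in place of hydrogen on an aromatic carbon, where the step of no change at the digits printed from compound 1 to compound 3 (within the scatter) holds for two compounds carrying the same 4-ethoxybutyl chain. Neither step lies beyond the scatter, so on this read-out neither the exchange of these two isomeric chains nor the addition of the carboxy group separates the compounds. Nothing available bears on why the values coincide.

As far as these compounds go, whether a chain of another kind at this position, such as a shorter propyl chain, a longer octyl chain or one ending in an amine, would keep the same read stays open. Also open, from the compounds shown here alone, is whether an amide or an ester in place of the carboxy group, or a nitrile in place of the nitro group, would leave the read where it stands.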